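Methoxy to iodo on the naphthyl ketone of compound 2

A few compounds are considered here, and "the series" means these few. Any claim that something is new, unique, unknown or untested is made for them only; others in the source may bear on it.

Measured so far:
compound 1 `Cc1sc(N)c(C(=O)c2cccc3ccccc23)c1C` gives 0%
compound 2 `COc1ccc(C(=O)c2c(N)sc3c2CCC3)c2ccccc12` gives 19%

In an assay on isolated protein with adenosine receptor A1 (Homo sapiens) as the target, tested at 10 uM (on this read-out higher numbers stand for more inhibition at the one concentration tested (going by the name of the read-out) and lower numbers for less inhibition), compound 2 gives 19%, the higher of the two numbers at hand; compound 1 gives 0%, a difference beyond the scatter. Both share the aminothiophene ketone core, and compound 2 carries the fused cyclopentane ring and the methoxy group.

Compound 3 `Nc1sc2c(c1C(=O)c1ccc(I)c3ccccc13)CCC2` is not yet measured. It differs from compound 2 in one place: iodo in place of methoxy on an aromatic carbon. Going by the values given here, no step between two measured compounds covers this exchange, so there is no number to lean on. The expectation is that the step of a number 1 percentage points higher from compound 2 to compound 3 (within the scatter) stays small, possibly none beyond the scatter, in either direction. Compound 3 is expected to give about 20% in this assay, within a range from 0% to 45%.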

Compound 3, a percentage reported as inhibition, at one concentration (the size of the read-out at that concentration, not a potency): 3.3%
Beside the measured number, compound 3's estimate is 16.7 percentage points above it; low and high end bracket the measured number.
By their numbers in this assay, from the lowest: compounds 1 and 3 (each within the scatter of the next); then compound 2.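

This carbon is not indifferent to its substituent: in this assay, iodo in place of methoxy, para to a large group, gives a step of a number 15.7 percentage points lower from compound 2 to compound 3 (beyond the scatter). Going by these compounds alone, the step is modest, but it is the first read between two measured compounds, and it shows that the inhibition of compound 2 at the one concentration tested does not survive this exchange. Nothing at hand bears on the reason for the step.

With only methoxy and iodo compared at this carbon, the compounds shown cannot tell whether the step follows from losing methoxy or from introducing iodo. Open too, going by these compounds, is how hydroxy, ethoxy, fluoro or an amine would read at the same carbon on the core of compound 2.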